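A few compounds are considered here, and "the series" means these few. Any claim that something is new, unique, unknown or untested is made for them only; others in the source may bear on it.

Two compounds of the series carry numbers in a functional assay for inhibition, tested at 60 ug/mL; on this read-out lower numbers stand for a weaker effect and higher numbers for a stronger effect at the one concentration tested. Compound 1 `Cc1cc(O)c(C(C)C)cc1-c1cc(-c2ccccc2[N+](=O)[O-])c(C#N)c(=O)[nH]1` gives 31%, and compound 2 `COc1cc(-c2cc(-c3cc(C(C)C)c(O)cc3C)[nH]c(=O)c2C#N)ccc1O` gives 37.5%. The single step between them, a number 6.5 percentage points higher from compound 1 to compound 2 (within the scatter), lies within the scatter, so although compound 2 holds the higher of the two numbers shown, the two compounds are not separated in this assay.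

Compound 3 `Cc1cc(O)c(C(C)C)cc1-c1cc(-c2ccc(N(C)C)cc2)c(C#N)c(=O)[nH]1` has not yet been measured. It differs from compound 2 in one place: 4-(dimethylamino)phenyl in place of 4-hydroxy-3-methoxyphenyl on an aromatic carbon. For the measured compounds named here, the only measured step that bears on this change is the exchange at the same aromatic carbon, a number 6.5 percentage points higher from compound 1 to compound 2 (within the scatter), which moved this assay by less than the scatter. Nothing measured distinguishes one aryl group from another at this place, and no number exists for the 4-(dimethylamino)phenyl group anywhere in the series. The step expected in this assay is therefore a number 3.5 percentage points lower from compound 2 to compound 3 (within the scatter), a shift that stays within the scatter, with no direction preferred. Compound 3 is accordingly estimated at 34%, with an expected range from 15% to 55%.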

Compound 3, a percentage reported as inhibition, at one concentration (the size of the read-out at that concentration, not a potency): 53%
For compound 3 the middle estimate is 19 percentage points below the measured one; the range from low to high includes it.
By their numbers in this assay, from the lowest: compounds 1 and 2 (each within the scatter of the next); then compound 3.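

In this assay, the aryl group on the aromatic carbon opposite the ring nitrogen can move the read-out beyond the scatter, which the earlier exchange at this place did not show: 4-(dimethylamino)phenyl in place of 4-hydroxy-3-methoxyphenyl gives a number 15.5 percentage points higher from compound 2 to compound 3 (beyond the scatter), and 4-(dimethylamino)phenyl in place of 2-nitrophenyl gives a number 22 percentage points higher from compound 1 to compound 3 (beyond the scatter). Compound 3 therefore stands apart from both earlier compounds, and its step from compound 2 comes with no change in the count of 9 heavy atoms, while the entering group has 0 hydrogen-bond donors and 1 hydrogen-bond acceptor against 1 and 2 in the group that leaves. No measurement on hand accounts for this step.

On these data alone, the exchange from 4-hydroxy-3-methoxyphenyl changes several features at once, so it remains open whether the dimethylamino group itself matters, a question that 4-aminophenyl, 4-(diethylamino)phenyl and 4-methoxyphenyl groups at the same place would address. As far as these compounds go, each number also comes from a single concentration, so the effect of these groups on potency stays open, as does whether a saturated amine such as piperidine could take the place of the aryl group.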